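The source may hold more compounds than are shown below. What is called first, only, known or untested is meant among the compounds shown, and "the series" means these compounds.

Compound 1 `COc1ccc(C(=O)c2ccc(OC)c3c2C=CC(C)(C)O3)c(NC(=O)CN)c1` gives 420 nM in a functional assay on A549 cells (Homo sapiens) for antiproliferative activity, read by MTT assay, with a stated time of 48 h; on this read-out lower numbers stand for stronger inhibition and higher numbers for weaker inhibition. Compound 2 `COc1ccc(C(=O)c2ccc3c(c2)C=CC(C)(C)O3)c(NC(=O)CN)c1` gives 310 nM in this assay; the difference between the cores of compound 1 and compound 2 is not broken down here. Compound 3 `CNCC(=O)Nc1cc(OC)ccc1C(=O)c1ccc(OC)c2c1C=CC(C)(C)O2` carries on the core of compound 1 the change (methyl in place of hydrogen on an amine nitrogen); in this assay compound 3 gives 1370 nM, so that a 3.3-fold higher number from compound 1 to compound 3 (0.51 log units; beyond the scatter). Compound 4 `CNCC(=O)Nc1cc(OC)ccc1C(=O)c1ccc2c(c1)C=CC(C)(C)O2` carries on the core of compound 2 the same change, methyl in place of hydrogen on an amine nitrogen with the amine nitrogen in the same surroundings in both cases; the change occurs twice among these compounds. For the measured compounds named here, a step of about the same size is expected from compound 2 to compound 4, namely a 3.2-fold higher number from compound 2 to compound 4 (0.51 log units; beyond the scatter), because a 3.3-fold higher number from compound 1 to compound 3 (0.51 log units; beyond the scatter) is the only measured instance of this change and nothing shows the core difference altering it. Compound 4 is therefore estimated at 1000 nM in this assay, within 500 nM to 2200 nM.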

Compound 4, half-maximal inhibitory concentration: 800 nM
Estimate against measurement, compound 4: 1.3-fold (0.10 log units) above, within the range that was stated.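

On the core of compound 2, methyl in place of hydrogen on the amine nitrogen gives a 2.6-fold higher number from compound 2 to compound 4 (0.41 log units; beyond the scatter) in this assay. The change carries from one of these cores to the other with no difference in size that can be told from the scatter: the same change on two cores in this assay, a 3.3-fold higher number (0.51 log units; beyond the scatter) from compound 1 to compound 3 and a 2.6-fold higher number (0.41 log units; beyond the scatter) from compound 2 to compound 4, 1.3-fold (0.10 log units) apart, within the scatter of two such steps

This rests on two pairs in a single assay, so it holds for the core of compound 1 and the core of compound 2 only, and it gives no reason for the weaker inhibition on methylation.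

The compounds shown leave open whether ethyl or a second methyl on this nitrogen would give a step of similar size. They also leave open how a longer chain in place of aminomethyl would behave on either core.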